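The compounds below may be only part of what the source reports. "The series", "measured", "known", "first", "only" and "open" are said of these compounds alone.

Working notes, measured in a functional assay on HL-60 cells (Homo sapiens) for cytotoxicity, read by luminescence and CellTiter-Glo, with a stated time of 3 days; on this read-out higher numbers stand for weaker inhibition and lower numbers for stronger inhibition

- compound 1 `N#Cc1ccc(NC(=O)c2cc(-c3cccnc3)ccc2O)cc1` gives 7960 nM
- compound 2 `N#Cc1ccc(NC(=O)c2cc(Cl)ccc2O)cc1` gives 700 nM
- compound 3 `N#Cc1ccc(NC(=O)c2c(O)cccc2F)cc1` gives > 10000 nM (a limit, not a number)

Compound 3 is known only as a limit (> 10000 nM). The set so far holds (the limit of > 10000 nM in this assay, at which 1 of the 3 values shown sits), and that reading belongs to compound 3, so any step out of it has no firm starting point.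

The next change leads to compound 4 `N#Cc1ccc(NC(=O)c2ccccc2O)cc1` and puts hydrogen in place of fluoro on an aromatic carbon. Within the data shown here, no measured step covers this exchange. Among the measured compounds shown here, the only measured step is a different one, chloro in place of pyridin-3-yl on an aromatic carbon, and it is large an 11-fold lower number from compound 1 to compound 2 (1.06 log units; beyond the scatter). It shows that one substituent on the shared core can move the number in this assay well beyond the scatter, but it gives neither the size nor the direction for losing fluoro.

A modest move toward a lower number is expected (an at least 1.6-fold lower number from compound 3 to compound 4 (0.22 log units; that floor lies within the scatter)), and the assay may again report only a limit. Compound 2 (700 nM) is not expected to be reached without its chloro. The estimated value for compound 4 is 6000 nM within an expected range from 2000 nM to 10000 nM.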

Compound 4, half-maximal inhibitory concentration: 4620 nM
Estimate against measurement, compound 4: 1.3-fold (0.11 log units) above; the measured number falls inside the stated range.
By their numbers in this assay, from the lowest: compound 2; then compounds 4 and 1 (each within the scatter of the next). At a limit, above all of these: compound 3.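

In this assay, hydrogen in place of fluoro gives an at least 2.1-fold lower number from compound 3 to compound 4 (0.33 log units; beyond the scatter), the first step at this position on the shared core, but it is a floor and not a size, since the starting reading for compound 3 is a limit: the limit of > 10000 nM in this assay, at which 1 of the 4 values shown sits.

Compound 4 also gives the shared core a reference without any substituent at the other changed carbon, and against it the chloro step reads as a 6.6-fold higher number from compound 2 to compound 4 (0.82 log units; beyond the scatter). The pyridin-3-yl step, by contrast, reads as a 1.7-fold lower number from compound 1 to compound 4 (0.24 log units; within the scatter), so the large gap between the two substituted compounds comes from the lower number that goes with chloro and not from a higher number that goes with pyridin-3-yl.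

On these data alone, the real size of the fluoro step stays open, and so does whether chloro on the carbon that carries fluoro in compound 3 would move the number the same way. As far as these compounds go, it also stays open whether a methyl, a methoxy or an amine on the carbon that carries chloro in compound 2 would track chloro or hydrogen.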